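Replacing a tert-butoxy group with a fused bicyclic amine

The source may hold more compounds than are shown below. What is called first, only, known or untested is meant among the compounds shown, and "the series" means these compounds.

Measured so far:
Compound 1, `COc1ccc2[nH]c(C(=O)N3CC(=O)N(Cc4cc5ccccc5[nH]4)[C@@H](Cc4ccccc4)C3)cc2c1`: 11000 nM
Compound 2, `COc1ccc2[nH]c(C(=O)N3CC(=O)N(Cc4ccccc4)[C@@H](COC(C)(C)C)C3)cc2c1`: 65500 nM

Going by the values given here, the two measured compounds share a core and differ in two places, so no single step can be drawn between them. In a physicochemical assay for solubility, read by spectrophotometry, in phosphate buffer, with a stated time of 2 h, at pH 7.4 (a lower number here means a less soluble compound, a higher number a more soluble compound), compound 2 stands highest of the two numbers, and compound 1, with a reading of 11000 nM in this assay, lies a good way below it, beyond the scatter of the method.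

The next compound, compound 3, `COc1ccc2[nH]c(C(=O)N3CC(=O)N(Cc4ccccc4)[C@@H](CN4CCCc5ccccc54)C3)cc2c1`, keeps the benzyl group of compound 2 and alters only the side chain: 1,2,3,4-tetrahydroquinolin-1-yl in place of tert-butoxy on a saturated chain carbon bound to a saturated ring carbon. The group that leaves carries no ring; the group that enters carries a non-aromatic ring with a hetero atom fused to an aromatic ring of carbon only.

Among the compounds with values here, with no step between measured compounds to lean on, the expectation rests on the spread of the two known values, with compound 1 at 11000 nM marking the lower end. Compound 3 is expected to fall in this assay by a 7.3-fold lower number from compound 2 to compound 3 (0.86 log units; beyond the scatter) from compound 2, a change beyond the scatter. The estimate for compound 3 is 9000 nM, in a range from 2500 nM to 30000 nM.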

Compound 3, solubility: 8500 nM
For compound 3 the middle estimate is 1.1-fold (0.02 log units) above the measured one, and the stated range covers the measured number.
By their numbers in this assay, from the lowest: compounds 3 and 1 (each within the scatter of the next); then compound 2.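

Going by these compounds alone, at the saturated chain carbon bound to a saturated ring carbon, putting 1,2,3,4-tetrahydroquinolin-1-yl in place of tert-butoxy gives a 7.7-fold lower number from compound 2 to compound 3 (0.89 log units; beyond the scatter) in this assay and provides the only change at a single place that can be read so far, showing that this position is not indifferent to the group it carries. The step comes with a larger group that brings in a six-membered non-aromatic ring and a six-membered aromatic ring, while the counts of hydrogen-bond donors and acceptors stay as they were and neither group carries a net charge. No measurement shown here accounts for the size or direction of this step.

From the compounds shown here alone, a single step cannot separate what the nitrogen, the non-aromatic ring and the aromatic ring each contribute, so it remains open how a simple amine such as piperidin-1-yl, or a carboxylic acid, would read at this position. Going by these compounds, it also remains open whether the same exchange would give a step of similar size with a group other than benzyl on the ring nitrogen of the shared core.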